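Capsaicin-like amides: methoxy additions and cytotoxicity

This account rests on a few compounds, and the source may have more. Where it says the series, first, only, none or still open, it means among the compounds named here.

Measured so far:
compound 1 `COc1cc(CNC(=O)/C=C/c2ccccc2OC)ccc1O` — 5980 nM
compound 2 `COc1cc(CNC(=O)/C=C/c2cccc(OC)c2OC)ccc1O` — 5490 nM
compound 3 `COc1cc(/C=C/C(=O)NCc2ccc(O)c(OC)c2)cc(OC)c1` — 4860 nM

All three were read in a functional assay on SH-SY5Y cells (Homo sapiens) for cytotoxicity, read by MTT assay, with stated times of 24 h and 4 h; a lower number here means that less compound is needed, a higher number that more compound is needed for the effect. Compound 1 gives 5980 nM, compound 2 gives 5490 nM and compound 3 gives 4860 nM; the three numbers lie within the scatter of one another, so no order among them can be stated.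

The change from compound 1 to compound 2 is methoxy in place of hydrogen on an aromatic carbon, and it made a 1.1-fold lower number from compound 1 to compound 2 (0.04 log units; within the scatter). Compound 4 `COc1cc(CNC(=O)/C=C/c2cc(OC)c(OC)c(OC)c2)ccc1O` is not yet measured; it arises from compound 3 by methoxy in place of hydrogen on an aromatic carbon. Among the measured compounds shown here, this is the same kind of change as the one from compound 1 to compound 2, but not the same: here the entering methoxy sits ortho to two methoxy groups and para to a large group, whereas in compound 2 it sits ortho to a methoxy group and meta to a large group. The difference between the core of compound 1 and the core of compound 3 is not broken down here.

For the measured compounds named here, because the only measured instance of this change, a 1.1-fold lower number from compound 1 to compound 2 (0.04 log units; within the scatter), stayed within the scatter, compound 4 is expected to show a step of about a 1.1-fold lower number from compound 3 to compound 4 (0.03 log units; within the scatter) in this assay. The estimate for compound 4 is 4500 nM, between 2500 nM and 8500 nM.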

Compound 4, half-maximal effective concentration: 5910 nM
For compound 4 the middle estimate is 1.3-fold (0.12 log units) below the measured one; low and high end bracket the measured number.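

In this assay, methoxy in place of hydrogen on an aromatic carbon, here entering ortho to two methoxy groups and para to a large group, made a 1.2-fold higher number from compound 3 to compound 4 (0.08 log units; within the scatter). Set beside the earlier instance, the step on the second core does not differ from the first beyond what repeated measurements allow: the same change on two cores in this assay, a 1.1-fold lower number (0.04 log units; within the scatter) from compound 1 to compound 2 and a 1.2-fold higher number (0.08 log units; within the scatter) from compound 3 to compound 4, 1.3-fold (0.12 log units) apart, within the scatter of two such steps. This shows that on these two cores the change leaves no readable effect, but with only two instances, both within the scatter, it does not show a direction for the change or that the same result would hold on a further core or at another place on the ring.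

Among the compounds shown, the ring that takes the change carries only methoxy groups as substituents. Open, then, is whether an amine, a carboxylic acid or a fluorine atom on that ring, or a longer alkoxy chain in place of a methoxy group, would give a step beyond the scatter.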